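The compounds below may be only part of what the source reports. "The series", "measured", "known", "first", "only" and "open" are said of these compounds alone.

Measured so far:
- compound 1 `Cc1ccc2nc(C(=O)Nc3c(F)cc(-c4cccc(F)c4)cc3F)c(C)c(O)c2c1`: 25.5%
- compound 2 `CCc1ccc2nc(C(=O)Nc3c(F)cc(-c4cccc(F)c4)cc3F)c(C)c(O)c2c1`: 46.3%
- compound 3 `Cc1ccc2nc(C(=O)Nc3c(F)cc(-c4cccc(F)c4)cc3F)c(C)c(C(=O)O)c2c1`: 35.6%

In a functional assay on Hep 3B2 cells (Homo sapiens) for antiproliferative activity, read by MTT assay, with a stated time of 24 h, tested at 11.11 ug/mL (on this read-out higher numbers stand for a stronger effect at the one concentration tested and lower numbers for a weaker effect), compound 3 stands second highest of the three numbers. Its nearest neighbour is compound 1, reached by a number 10.1 percentage points higher from compound 1 to compound 3 (beyond the scatter); compound 2 lies furthest away, and the values of compound 2 and compound 3 show compound 2 on the higher side.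

Compound 4 `Cc1c(C(=O)Nc2c(F)cc(-c3cccc(F)c3)cc2F)nc2ccc(F)cc2c1C(=O)O` has not yet been tested in this assay. It differs from compound 3 at one spot: fluoro in place of methyl on an aromatic carbon. For the measured compounds named here, only one measured step touches this part of the shared core, a number 20.8 percentage points higher from compound 1 to compound 2 (beyond the scatter), where lengthening the chain on the same site raised the number by a modest amount. Going by the values given here, no measured step exchanges a methyl for a fluoro anywhere, so the direction of the change in compound 4 rests on thin ground. A step of at most modest size is therefore expected, quite possibly none beyond the scatter, and the estimate for compound 4 is 28% with a range from 10% to 48%, meaning an expected step of a number 7.6 percentage points lower from compound 3 to compound 4 (within the scatter).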

Compound 4, a percentage reported as inhibition, at one concentration (the size of the read-out at that concentration, not a potency): 26.3%
Estimate against measurement, compound 4: 1.7 percentage points above, within the range that was stated.
By their numbers in this assay, from the lowest: compounds 1, 4 and 3 (each within the scatter of the next, the first and the last beyond it); then compound 2.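

In this assay the exchange of methyl for fluoro on this aromatic carbon gives a small step (a number 9.3 percentage points lower from compound 3 to compound 4 (within the scatter)), so in the carboxy compounds this change cannot be told apart from the usual scatter. Until now this carbon had been seen to change only from methyl to ethyl, on the hydroxy compounds, and that step did clear the scatter (a number 20.8 percentage points higher from compound 1 to compound 2 (beyond the scatter)). No measurement is at hand that could explain either outcome.

Still open, going by these compounds, is whether fluoro in place of methyl would also stay within the scatter on the hydroxy compounds, where the substituent on this carbon has so far made a clear difference. Also open, on these data alone, is how a chain longer than ethyl, such as propyl, or a methoxy group or an amine on this carbon would behave.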